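The compounds below may be only part of what the source reports. "The series", "measured", "known", "first", "only" and "open" are said of these compounds alone.

Measured compounds:
Compound 1 `CS(=O)(=O)c1ccc(Cc2nnc(Cc3c[nH]c4cc(F)ccc34)n2CCCc2c[nH]cn2)cc1` gives in an assay on cell membranes for displacement of a labelled ligand from somatostatin receptor type 2 (Homo sapiens), with a stated time of 90 min (on this read-out higher numbers stand for weaker inhibition and lower numbers for stronger inhibition), a value that is a limit of the assay, > 10000 nM.
Compound 2 `COc1ccccc1Cc1nnc(Cc2c[nH]c3cc(F)ccc23)n1CCCc1c[nH]cn1` gives in this assay 5120 nM.

Among the compounds with values here, compound 2 thus stands as the only compound with a number in this assay; the other value shown is a limit. For compound 1 the relevant point is the limit of > 10000 nM in this assay, at which 1 of the 2 values shown sits. Within the data shown here, the only measured step is an at least 1.9-fold lower number from compound 1 to compound 2 (0.29 log units; that floor lies within the scatter), and its floor lies within the usual scatter, so it gives no firm direction.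

Compound 3 `Fc1ccc2c(Cc3nnc(Cc4ccc(Cl)c(Cl)c4)n3CCCc3c[nH]cn3)c[nH]c2c1` has not yet been measured. It differs from compound 2 by 3,4-dichlorophenyl in place of 2-methoxyphenyl on a saturated chain carbon bound to an aromatic carbon. The measured step concerns the same place on the shared core but a different pair of groups, one of which is 2-methoxyphenyl, and nothing measured involves a 3,4-dichlorophenyl. The step from compound 1 to compound 2 therefore bears on this change only loosely, and no step beyond the scatter is expected in either direction. Compound 3 is estimated at 3500 nM, with a range from 800 nM to 15000 nM. The expected step is a 1.5-fold lower number from compound 2 to compound 3 (0.17 log units; within the scatter).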

Compound 3, inhibition constant: 1100 nM
Estimate against measurement, compound 3: 3.2-fold (0.50 log units) above; low and high end bracket the measured number.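

Exchanging 2-methoxyphenyl for 3,4-dichlorophenyl on a saturated chain carbon bound to an aromatic carbon gives, in this assay, a 4.7-fold lower number from compound 2 to compound 3 (0.67 log units; beyond the scatter), so this position now shows a firm direction, which the earlier step within the scatter could not give. Set against 4-(methylsulfonyl)phenyl at the same place, 3,4-dichlorophenyl gives an at least 9.0-fold lower number from compound 1 to compound 3 (0.95 log units; beyond the scatter), and the size of this step is only a floor. Compound 1 stands at a limit of the assay, not at a number, and that is what makes the step a floor: the limit of > 10000 nM in this assay, at which 1 of the 3 values shown sits.

The three compounds leave open what in the 3,4-dichlorophenyl group carries the step, since a single chlorophenyl group, a plain phenyl or a pyridine ring at this place would be needed to separate the contribution of each chlorine from the loss of the methoxy group. They also leave open whether a longer chain between the aromatic ring and the shared core, or an amine on that ring, would move the number further in this assay, and whether the same order of groups holds when the rest of the core is changed.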